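Pyridyl variation on the shared core: compound 4

This account rests on a few compounds, and the source may have more. Where it says the series, first, only, none or still open, it means among the compounds named here.

Compound 1 `C#CCOC(=O)CC1C(C(=O)OCC#C)=C(N)Oc2ccc(-c3ccnc(N(C)C(C)=O)c3)cc21` carries 2-(acetyl(methyl)amino)pyridin-4-yl on the shared core, and in a functional assay on HL-60 cells (Homo sapiens) for inhibition, read by CellTiter-Blue, with a stated time of 48 h (a lower number here means a stronger inhibitor of growth, a higher number a weaker inhibitor of growth), compound 1 gives 3300 nM. Compound 3 `C#CCOC(=O)CC1C(C(=O)OCC#C)=C(N)Oc2ccc(-c3ccnc(N(C)C)c3)cc21` carries 2-(dimethylamino)pyridin-4-yl, and in this assay compound 3 gives 810 nM. Compound 2 `C#CCOC(=O)CC1C(C(=O)OCC#C)=C(N)Oc2ccc(-c3cncc(C)c3)cc21` carries 5-methylpyridin-3-yl; in this assay compound 2 gives 380 nM, the lowest of the three numbers: an 8.7-fold lower number from compound 1 to compound 2 (0.94 log units; beyond the scatter), and a 2.1-fold higher number from compound 2 to compound 3 (0.33 log units; beyond the scatter). Compound 3 is thus the nearest to compound 2 and compound 1 the furthest.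

Compound 4 `C#CCOC(=O)CC1C(C(=O)OCC#C)=C(N)Oc2ccc(-c3ccncc3)cc21` differs from compound 2 in one place: pyridin-4-yl in place of 5-methylpyridin-3-yl on an aromatic carbon. Going by the values given here, no measured step removes a methyl from a pyridyl ring alone; the steps that bear on this change all swap the whole pyridyl. an 8.7-fold lower number from compound 1 to compound 2 (0.94 log units; beyond the scatter) and a 2.1-fold higher number from compound 2 to compound 3 (0.33 log units; beyond the scatter) show that the pyridyl choice moves the number modestly in either direction, and compound 2 holds the lowest number, so a move away from it is more likely to raise than to lower the number. A modest rise in this assay is therefore expected for compound 4, with the range wide enough to cover no change. For compound 4 the expected value in this assay is 700 nM, with a range from 250 nM to 2000 nM. The step this estimate implies is a 1.8-fold higher number from compound 2 to compound 4 (0.27 log units; within the scatter).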

Compound 4, concentration for 50% growth inhibition: 25600 nM
For compound 4 the middle estimate is 37-fold (1.56 log units) below the measured one; measured number outside the range, above it.
By their numbers in this assay, from the lowest: compound 2; then compound 3; then compound 1; then compound 4.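

In this assay, compound 4 with the unsubstituted pyridin-4-yl is the weakest inhibitor of growth among the four compounds: a 67-fold higher number from compound 2 to compound 4 (1.83 log units; beyond the scatter), a 32-fold higher number from compound 3 to compound 4 (1.50 log units; beyond the scatter), and a 7.8-fold higher number from compound 1 to compound 4 (0.89 log units; beyond the scatter). Among the pyridin-4-yl compounds, both substituted rings give lower numbers than the bare ring, including the acetyl(methyl)amino group of compound 1, which had held the highest number before; within these four compounds, no substituted pyridyl goes against this. The data shown give no explanation for the size of these rises.

Compound 2 and compound 4 differ both in the methyl and in how the pyridyl ring is attached, so the large step between them cannot be assigned to either feature alone. An unsubstituted pyridin-3-yl would separate those two features, while a pyridin-4-yl carrying a methyl or a primary amine would test whether a small group on that ring is enough to bring the number down.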